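Adding Methoxy to a Nitro Compound at the Assay Limit

The compounds below may be only part of what the source reports. "The series", "measured", "known", "first", "only" and "open" are said of these compounds alone.

In a functional assay on L1210 cells (Mus musculus) for antiproliferative activity, read by MTT assay, with a stated time of 72 h (a lower number here means a stronger inhibitor, a higher number a weaker inhibitor), compound 1 (`COc1cc(/C(=C/c2ccc(Cl)cc2)C(C)O)cc(OC)c1OC`) gives > 100000 nM, which is a limit and not a number. Compound 2 (`COc1cc(/C(=C/c2ccc(Br)cc2)C(C)O)cc(OC)c1OC`) gives > 100000 nM, again a limit. Compound 3 (`COc1cc(/C(=C/c2cccc([N+](=O)[O-])c2)C(C)O)cc(OC)c1OC`) gives > 100000 nM, also a limit, so its standing is known only as the limit of > 100000 nM in this assay, at which 3 of the 3 values shown sit.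

Compound 4 (`COc1ccc(/C=C(/c2cc(OC)c(OC)c(OC)c2)C(C)O)cc1[N+](=O)[O-]`) carries methoxy in place of hydrogen on an aromatic carbon, ortho to a nitro group and para to a large group: methoxy in place of hydrogen on an aromatic carbon.

Within the data shown here, only one measured step is available, a step that the two limits leave unreadable from compound 1 to compound 2, and it is a bromo in place of chloro exchange rather than this change. Among the measured compounds shown here, it gives no size to carry over, and no measured step shows what a methoxy does here. For the measured compounds named here, no step of a particular size or direction can therefore be expected in this assay, and compound 4 is expected to stay near the limit.

For compound 4, the expected step is a number no higher from compound 3 to compound 4 (the limit leaves the size open).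

The estimated value for compound 4 is 100000 nM, with an expected range of 20000 nM to 200000 nM.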

Compound 4, half-maximal inhibitory concentration: 67500 nM
Estimate against measurement, compound 4: 1.5-fold (0.17 log units) above; low and high end bracket the measured number.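

In this assay, compound 4 is the first of the compounds shown to give a number and not a limit, so a methoxy on this aromatic carbon, ortho to a nitro group and para to a large group, gives the first result that can be read as a number. The change gives an at least 1.4-fold lower number from compound 3 to compound 4 (0.17 log units; that floor lies within the scatter). This is a floor and not a measured size, and the step among the earlier compounds cannot be read, so the rest of the series offers no size to set beside it: the limit of > 100000 nM in this assay, at which 3 of the 4 values shown sit.

From the compounds shown here alone, the true size of the step stays open, as does whether it would hold without the nitro group. Also open, going by these compounds, is whether an amine or a carboxylic acid on the same aromatic carbon would give a readable number in this assay.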